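The compounds below may be only part of what the source reports. "The series", "measured", "known", "first", "only" and "open" are said of these compounds alone.

Measured so far in a functional assay on HL-60 cells (Homo sapiens) for cytotoxicity, read by MTT assay, with a stated time of 48 h; a higher number here means a weaker inhibitor, a lower number a stronger inhibitor:
compound 1, `O=c1ccc2cc(OCc3cc(-c4ccccc4Cl)no3)ccc2o1`, with "not determined" (no result reported), meaning that no result was reported for it;
compound 2, `COc1ccc(-n2cc(COc3ccc4oc(=O)ccc4c3)nn2)cc1`, with 46400 nM;
compound 3, `O=c1ccc2cc(OCc3cn(-c4cccc([N+](=O)[O-])c4)nn3)ccc2o1`, with 20500 nM.

Compound 3 holds the lowest of the two numbers in this assay. Going by the values given here, its nearest neighbour is compound 2, and the single measured step between them, a 2.3-fold lower number from compound 2 to compound 3 (0.35 log units; beyond the scatter), was modest but beyond the scatter; it came from putting 3-nitrophenyl in place of 4-methoxyphenyl on an aromatic nitrogen.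

Compound 4, `N#Cc1ccccc1-n1cc(COc2ccc3oc(=O)ccc3c2)nn1`, differs from compound 3 in one place: 2-cyanophenyl in place of 3-nitrophenyl on an aromatic nitrogen. Among the compounds with values here, the only step that bears on this position is the exchange of one aryl group on the aromatic nitrogen just described, and it moved the number only modestly. Within the data shown here, no measured compound carries a 2-cyanophenyl group, so the new exchange has no matching step of its own to lean on; on this thin basis it is expected to stay within the scatter, with no clear direction, which means a 1.2-fold higher number from compound 3 to compound 4 (0.07 log units; within the scatter). Compound 4 is therefore estimated at 24000 nM, with a range from 8000 nM to 70000 nM.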

Compound 4, half-maximal inhibitory concentration: 52100 nM
The estimate for compound 4 lay 2.2-fold (0.34 log units) below the measured number; low and high end bracket the measured number.
By their numbers in this assay, from the lowest: compound 3; then compounds 2 and 4 (each within the scatter of the next).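

In this assay, the aryl group on the aromatic nitrogen now shows a second modest exchange beyond the scatter: 2-cyanophenyl in place of 3-nitrophenyl gives a 2.5-fold higher number from compound 3 to compound 4 (0.41 log units; beyond the scatter). Set against the other aryl group, 2-cyanophenyl in place of 4-methoxyphenyl gives a 1.1-fold higher number from compound 2 to compound 4 (0.05 log units; within the scatter), so among these three groups only the 3-nitrophenyl of compound 3 stands apart, while the 2-cyanophenyl and 4-methoxyphenyl groups cannot be told apart. Nothing available explains why the 3-nitrophenyl group differs from the other two.

The compounds shown leave open whether the nitro group or its place on the phenyl ring sets this difference, since 3-cyanophenyl and 2-nitrophenyl do not appear among them. They also leave open how an amine or a carboxylic acid on that phenyl ring would compare.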